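Spiro-lactone dienones: swapping the benzofuranyl for methoxyphenyl

The source may hold more compounds than are shown below. What is called first, only, known or untested is meant among the compounds shown, and "the series" means these compounds.

Measured so far:
compound 1 `COc1ccc(OC(=O)C#Cc2ccccc2)cc1` — 6660 nM
compound 2 `O=C1C=CC2(C=C1)OC(=O)C(c1cc3ccccc3o1)=C2c1ccccc1` — 21200 nM

In a functional assay on MDA-MB-231 cells (Homo sapiens) for antiproliferative activity, read by MTT assay, with a stated time of 48 h (a lower number here means a stronger inhibitor, a higher number a weaker inhibitor), compound 2 gives the highest of the two numbers recorded; the nearest is compound 1, whose number is lower by a step beyond the usual scatter. Compound 1 and compound 2 share no common core, so the two values only show where each stands and do not define a step.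

Compound 3 `COc1ccc(C2=C(c3ccccc3)C3(C=CC(=O)C=C3)OC2=O)cc1` differs from compound 2 in one place: 4-methoxyphenyl in place of 1-benzofuran-2-yl on a double-bonded ring carbon. For the measured compounds named here, no pair of measured compounds reports this exchange on the shared core, so the size of the step is open. Given the standing of compound 2 at 21200 nM, the expectation for compound 3 is a number near that of compound 2, not beyond the scatter, with a modest downward lean. Compound 3 is expected at 15000 nM, with a range from 5000 nM to 45000 nM, an estimated step of a 1.4-fold lower number from compound 2 to compound 3 (0.15 log units; within the scatter).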

Compound 3, half-maximal inhibitory concentration: 64000 nM
The estimate for compound 3 lay 4.3-fold (0.63 log units) below the measured number, outside the stated range (above it).
By their numbers in this assay, from the lowest: compound 1; then compound 2; then compound 3.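

On the double-bonded ring carbon of the shared core, 4-methoxyphenyl in place of 1-benzofuran-2-yl gives a 3.0-fold higher number from compound 2 to compound 3 (0.48 log units; beyond the scatter) in this assay, so this position is sensitive to the group it carries. For the compounds shown here, this is the first step that can be read on the shared core, and it runs towards weaker inhibition, leaving 1-benzofuran-2-yl the better of the two groups at this position. Nothing available bears on the origin of this step.

A single pair cannot separate the loss of 1-benzofuran-2-yl from the arrival of 4-methoxyphenyl. From the compounds shown here alone, whether an unsubstituted phenyl, a phenyl bearing an amine or a carboxylic acid, or another five-membered aromatic ring at this carbon would lower the number remains open.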